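Fluoro for Methyl at the Limit of Measurement

The compounds below may be only part of what the source reports. "The series", "measured", "known", "first", "only" and "open" are said of these compounds alone.

Compound 1 `COc1cc(-c2nnc(SCC(=O)c3ccc(Br)cc3)n2N)cc(OC)c1OC` gives 10400 nM in a functional assay on HeLa cells (Homo sapiens) for antiproliferative activity, read by MTT assay, with a stated time of 48 h (on this read-out higher numbers stand for weaker inhibition and lower numbers for stronger inhibition), and compound 2 `COc1cc(-c2nnc(SCC(=O)c3cccc(Br)c3)n2N)cc(OC)c1OC` gives 77500 nM. Compound 3 `COc1cc(-c2nnc(SCC(=O)Nc3ccccc3C)n2N)cc(OC)c1OC` gives > 100000 nM in this assay, which is a limit of the assay rather than a measured number, as noted in the limit of > 100000 nM in this assay, at which 1 of the 3 values shown sits. The measured steps within the set are a 7.5-fold higher number from compound 1 to compound 2 (0.87 log units; beyond the scatter), an at least 9.6-fold higher number from compound 1 to compound 3 (0.98 log units; beyond the scatter) and an at least 1.2-fold higher number from compound 2 to compound 3 (0.11 log units; that floor lies within the scatter). Compound 4 `COc1cc(-c2nnc(SCC(=O)Nc3ccccc3F)n2N)cc(OC)c1OC` differs from compound 3 by fluoro in place of methyl on an aromatic carbon. Among the compounds with values here, none of the measured steps touches that ring, so they give no direct guidance on this change. Compound 4 is therefore expected to show a step that the limit leaves unreadable from compound 3 to compound 4, nothing beyond the scatter. The estimated value for compound 4 is 120000 nM, between 40000 nM and 400000 nM.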

Compound 4, half-maximal inhibitory concentration: 38200 nM
Compound 4: middle estimate off by 3.1-fold (0.50 log units), on the high side; measured number outside the range, below it.
By their numbers in this assay, from the lowest: compound 1; then compound 4; then compound 2. At a limit, above all of these: compound 3.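

Compound 3 stands only at a limit of the assay: the limit of > 100000 nM in this assay, at which 1 of the 4 values shown sits. Fluoro in place of methyl on this aromatic carbon gives an at least 2.6-fold lower number from compound 3 to compound 4 (0.41 log units; beyond the scatter), so this position responds to a change of one atom, and a (2-phenyl)amino-type compound now has a readable number. Against the bromophenyl compounds, the (2-fluorophenyl)amino group gives a 2.0-fold lower number from compound 2 to compound 4 (0.31 log units; beyond the scatter) and a 3.7-fold higher number from compound 1 to compound 4 (0.57 log units; beyond the scatter).

As far as these compounds go, what chloro, methoxy or an amine at this place would give stays open. The full size of the change from methyl to fluoro is known only as a floor.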